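Methoxy to isobutoxy on compound 1

The compounds below may be only part of what the source reports. "The series", "measured", "known", "first", "only" and "open" are said of these compounds alone.

For the measured compounds named here, in a functional assay on HCT-8 cells (Homo sapiens) for antiproliferative activity, read by sulforhodamine B assay, with a stated time of 3 days (a higher number here means that more compound is needed for the effect, a lower number that less compound is needed), compound 1 (`CCCC1=C(OC)C(CCC)(CCC)C(=O)/C(=C(O)\C=C\c2ccccc2)C1=O`) gives 3.5 uM, the lower of the two numbers so far. Compound 2 (`COC1=C(CC(C)C)C(=O)/C(=C(O)/C=C/c2ccccc2)C(=O)C1(CC(C)C)CC(C)C`) gives 7.5 uM, a gap beyond the usual scatter, and it carries a methoxy group as well. Compound 3 (`CCCC1=C(OCC(C)C)C(CCC)(CCC)C(=O)/C(=C(O)\C=C\c2ccccc2)C1=O`) keeps the core of compound 1 and alters one group: isopropyl in place of hydrogen on a saturated chain carbon bound to an oxygen on an unsaturated carbon, or methoxy to isobutoxy. Going by the values given here, no measured pair tests this change, so the expectation is loose. A small rise in the number is expected, possibly none beyond the scatter. The estimated step is a 1.4-fold higher number from compound 1 to compound 3 (0.15 log units; within the scatter). For compound 3 the estimate is 5 uM, with an expected range from 2 uM to 13 uM.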

Compound 3, concentration for half-maximal effect: 8 uM
For compound 3 the middle estimate is 1.6-fold (0.20 log units) below the measured one, within the range that was stated.
By their numbers in this assay, from the lowest: compound 1; then compounds 2 and 3 (each within the scatter of the next).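

In this assay the change from methoxy to isobutoxy gives the series its first single-change reading at this place, on a saturated chain carbon bound to an oxygen on an unsaturated carbon: a 2.3-fold higher number from compound 1 to compound 3 (0.36 log units; beyond the scatter) is a modest step beyond the scatter. The isopropyl added here therefore costs some activity without abolishing it, so this place accepts a larger group on the core of compound 1. No measurement at hand bears on what lies behind this step.

With a single replacement at this place, the compounds shown leave open how a straight butyl chain, a benzyl group or a chain ending in an amine or a carboxylic acid would read there. They also leave open whether methoxy to isobutoxy gives a similar step on the core of compound 2.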